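Working notes on a diaryl ether series: nitrogen methyl removal

This account rests on a few compounds, and the source may have more. Where it says the series, first, only, none or still open, it means among the compounds named here.

Measured so far:
compound 1 `CN(c1ccc(Oc2ncnc3ccsc23)cc1)c1nccc(N2CCCC2)n1`: 38%
compound 2 `CN(c1ccc(Oc2ncnc3sccc23)cc1)c1nccc(N2CCCC2)n1`: 31%

In a functional assay on MDA-MB-231 cells (Homo sapiens) for inhibition, read by MTT assay, with a stated time of 72 h, tested at 20 uM (on this read-out higher numbers stand for more inhibition at the one concentration tested (going by the name of the read-out) and lower numbers for less inhibition), compound 1 gives 38% and compound 2 gives 31%; the step of a number 7 percentage points lower from compound 1 to compound 2 (within the scatter) is within the scatter, so the two stand level. Compound 3 `c1cc(N2CCCC2)nc(Nc2ccc(Oc3ncnc4ccsc34)cc2)n1` differs from compound 1 by hydrogen in place of methyl on a nitrogen on an aromatic ring. Among the measured compounds shown here, the single measured step concerns the group of nine heavy atoms on the ether oxygen, not this nitrogen, so no measured pair bears on the change. No step beyond the scatter is therefore expected in this assay. For compound 3 the expected value is 38%, between 15% and 60%. The expected step is no change at the digits printed from compound 1 to compound 3 (within the scatter).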

Compound 3, a percentage reported as inhibition, at one concentration (the size of the read-out at that concentration, not a potency): 14.3%
Compound 3: middle estimate off by 23.7 percentage points, on the high side; the whole stated range lies above it.
By their numbers in this assay, from the lowest: compound 3; then compounds 2 and 1 (each within the scatter of the next).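

In this assay, among the compounds shown here, hydrogen in place of methyl on a nitrogen on an aromatic ring gives a number 23.7 percentage points lower from compound 1 to compound 3 (beyond the scatter) and is the first step beyond the scatter. The earlier pair differed only in the group on the ether oxygen and stood level, so this nitrogen is the first place shown to move the number. Nothing at hand accounts for the loss.

Still open, going by these compounds, is whether the same change on the core of compound 2 gives a similar step. Also open, on these data alone, is whether an ethyl group or a longer chain on this nitrogen keeps the level of compound 1.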